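The source may report more compounds than this note shows. Statements on the series, on what has been measured and on what is new or still open speak of the compounds shown alone.

Compound 1 `CC(=O)O[C@H](CCc1ccc(O)cc1)C[C@H](O)CCc1ccc(O)cc1`: in a functional assay on RAW264.7 cells (Mus musculus) for inhibition, read by spectrophotometry and Griess assay, with a stated time of 24 h (on this read-out lower numbers stand for stronger inhibition and higher numbers for weaker inhibition), compound 1 gives 32000 nM.
Compound 2 `Oc1ccc(CC[C@@H](O)C[C@H](O)CCc2ccc(O)cc2)cc1`: in this assay compound 2 gives only a limit, > 100000 nM.

For the measured compounds named here, compound 1 holds the only real number in this assay; the one other result is a limit. Going by the values given here, the single measured step, an at least 3.1-fold higher number from compound 1 to compound 2 (0.49 log units; beyond the scatter), concerns an oxygen on a saturated carbon. Compound 3 `CC(=O)O[C@H](CCc1ccc(O)c(O)c1)C[C@H](O)CCc1ccc(O)cc1` differs from compound 1 elsewhere: hydroxy in place of hydrogen on an aromatic carbon. Among the compounds with values here, no measured step touches an aromatic carbon, so none bears on this change, and no shift beyond the scatter is expected, a 1.3-fold lower number from compound 1 to compound 3 (0.11 log units; within the scatter). Compound 3 is therefore estimated at 25000 nM in this assay, expected within 8000 nM to 80000 nM.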

Compound 3, half-maximal inhibitory concentration: 9520 nM
Estimate against measurement, compound 3: 2.6-fold (0.42 log units) above; the measured number falls inside the stated range.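

In this assay, for the compounds shown here, changing 4-hydroxyphenyl to 3,4-dihydroxyphenyl gives a 3.4-fold lower number from compound 1 to compound 3 (0.53 log units; beyond the scatter), so the aromatic ring also responds to substitution, which the earlier compounds, differing only at the acetylated oxygen, could not show. The step is modest, but in these compounds the read-out depends on the ring as well as on the acetyl group. Nothing shown here accounts for this shift. Going by these compounds, whether a methoxy group, a fluorine or an amine at this place would act like hydroxy remains open, as does the effect of the same hydroxy on the other aromatic ring.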